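The source may hold more compounds than are shown below. What is called first, only, known or untested is meant among the compounds shown, and "the series" means these compounds.

Measured so far:
Compound 1, `CCN(CC)CN1C(=O)/C(=N/NC(N)=S)c2cc(Cl)ccc21` — in a functional assay on L1210 cells (Mus musculus) for inhibition, read by cell counting, with a stated time of 48 h (a lower number here means a stronger inhibitor, a higher number a weaker inhibitor), compound 1 gives 148000 nM
Compound 2, `CCN(CC)CN1C(=O)/C(=N/NC(N)=S)c2ccccc21` — in this assay compound 2 gives 121000 nM

Within the data shown here, compound 1 has the higher of the two numbers, but the only measured step, a 1.2-fold lower number from compound 1 to compound 2 (0.09 log units; within the scatter), stays within the scatter, so the two compounds cannot be ordered. Compound 3, `CCN(CC)CN1C(=O)/C(=N/NC(=S)Nc2ccccc2)c2cc(Cl)ccc21`, differs from compound 1 as follows: phenyl in place of hydrogen on an amide-type nitrogen. Among the measured compounds shown here, the one measured step concerns hydrogen in place of chloro on an aromatic carbon and has no bearing on the thiocarbonyl-bound nitrogen, so no measured step guides this change. An enlargement of compound 1 to compound 3 of a 2.1-fold lower number from compound 1 to compound 3 (0.33 log units; beyond the scatter) is nonetheless expected, with wide uncertainty. Compound 3 is thus estimated at 70000 nM in this assay, within 15000 nM to 250000 nM.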

Compound 3, half-maximal inhibitory concentration: 49000 nM
The estimate for compound 3 lay 1.4-fold (0.15 log units) above the measured number, and the stated range covers the measured number.
By their numbers in this assay, from the lowest: compound 3; then compounds 2 and 1 (each within the scatter of the next).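

In this assay, among these compounds, phenyl in place of hydrogen on the amide-type nitrogen gives a 3.0-fold lower number from compound 1 to compound 3 (0.48 log units; beyond the scatter), the only step so far that lies beyond the scatter. This shows that the number at this nitrogen can change, and that adding an aromatic ring here lowers it, if only modestly. Nothing available explains this step. On these data alone, whether a methyl or a benzyl group on this nitrogen would also lower the number stays open. So does whether phenyl would give a similar step on compound 2, which carries hydrogen in place of chloro.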